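This account rests on a few compounds, and the source may have more. Where it says the series, first, only, none or still open, it means among the compounds named here.

Compound 1 `Cc1cccc(C(=O)NCN2CCC(c3nccs3)CC2)c1` was examined in a functional assay on HEK293 cells for agonist activity at D(4) dopamine receptor (Homo sapiens), read by FLIPR (on this read-out lower numbers stand for an effect already at smaller amounts and higher numbers for an effect only at larger amounts of compound), where compound 1 gives 9.8 nM. Among the three measured compounds it stands second highest. Compound 3 `Cc1cccc(NC(=O)CN2CCC(c3ccccc3C#N)CC2)c1` gives 8 nM in this assay, and the two values fall within the usual scatter of each other, so no difference can be claimed between them. Compound 2 `O=C(CN1CCC(c2cccc[n+]2[O-])CC1)Nc1ccccc1F` gives 270 nM in this assay, a number beyond the scatter above compound 1, so compound 2 acts only at clearly larger amounts than compound 1.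

The unmeasured compound 4 `COc1ccccc1C1CCN(CNC(=O)c2cccc(C)c2)CC1` differs from compound 1 in one place: 2-methoxyphenyl in place of 1,3-thiazol-2-yl on a saturated ring carbon. Among the measured compounds shown here, no pair of measured compounds shares exactly this change, so its effect is unknown. Compound 3, however, also carries a six-membered aromatic ring of carbon with one substituent on that saturated ring carbon, and its value in this assay sits close to that of compound 1. A step from compound 1 to compound 4 of about a 1.5-fold higher number from compound 1 to compound 4 (0.18 log units; within the scatter) is therefore expected, hardly beyond the scatter. Compound 4 is estimated at 15 nM in this assay, within a range from 4 nM to 60 nM.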

Compound 4, half-maximal effective concentration: 206 nM
For compound 4 the middle estimate is 14-fold (1.14 log units) below the measured one; the measured number lies above the stated range.
By their numbers in this assay, from the lowest: compounds 3 and 1 (each within the scatter of the next); then compounds 4 and 2 (each within the scatter of the next).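

With the rest of compound 1 unchanged, replacing 1,3-thiazol-2-yl on the saturated ring carbon with 2-methoxyphenyl gives in this assay a 21-fold higher number from compound 1 to compound 4 (1.32 log units; beyond the scatter) and moves the effect to clearly larger amounts of compound. This single change is therefore enough to produce a large step, so this position does not treat these two aromatic groups alike. The change alters the ring size, the ring atoms and the attached methoxy group all at once, and no measurement at hand explains the rise.

Still open, on these data alone, is whether the rise follows from losing the 1,3-thiazol-2-yl group or from adding the methoxy group. A plain phenyl ring at this position could separate those two possibilities, and a pyridin-2-yl ring could show how a six-membered ring containing nitrogen behaves there.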